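From hydroxy to nitro in a cytotoxic series

The compounds below may be only part of what the source reports. "The series", "measured", "known", "first", "only" and "open" are said of these compounds alone.

- Compound 1 `COc1ccc(-c2cnnn2Cc2cc(OC)c(OC)c(OC)c2)cc1` gives 5560 nM
- Compound 2 `COc1ccc(-c2cnnn2Cc2cc(OC)c(OC)c(OC)c2)cc1Br` gives > 10000 nM (a limit of the assay, not a number)
- Compound 3 `COc1ccc(-c2cnnn2Cc2cc(OC)c(OC)c(OC)c2)cc1O` gives 530 nM

All three were tested in a functional assay on K562 cells (Homo sapiens) for cytotoxicity, read by MTT assay, with a stated time of 5 days (a lower number here means a stronger inhibitor, a higher number a weaker inhibitor), and compound 3 is the strongest of them, as the steps of a 10-fold lower number from compound 1 to compound 3 (1.02 log units; beyond the scatter) and an at least 18-fold lower number from compound 2 to compound 3 (1.27 log units; beyond the scatter) show. Bromo in place of hydrogen brought no clear change, with an at least 1.7-fold higher number from compound 1 to compound 2 (0.25 log units; that floor lies within the scatter) as its step.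

Compound 4 `COc1ccc(-c2cnnn2Cc2cc(OC)c(OC)c(OC)c2)cc1[N+](=O)[O-]` has nitro in place of hydroxy on an aromatic carbon, and the count is nitro in place of hydroxy on an aromatic carbon here. Among the compounds with values here, only hydroxy has lowered the number so far, so losing it should undo most of that large gain, and compound 4 is expected to land nearer compound 1 than compound 3. The expected change is a 7.5-fold higher number from compound 3 to compound 4 (0.88 log units; beyond the scatter) in this direction. The estimate for compound 4 is 4000 nM with an expected range from 1200 nM to 10000 nM in this assay.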

Compound 4, half-maximal inhibitory concentration: > 10000 nM
Compound 4: a limit, no number; the forecaster's own chance of this, stated with the estimate: 25%; at least 2.5-fold (0.39 log units) between middle value and limit.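

In this assay, nitro does not keep the large gain seen with hydroxy at this position, ortho to a methoxy group: the step is an at least 18-fold higher number from compound 3 to compound 4 (1.27 log units; beyond the scatter). Nitro also shows no clear change from hydrogen, with an at least 1.7-fold higher number from compound 1 to compound 4 (0.25 log units; that floor lies within the scatter), so of the groups shown here only hydroxy lowers the number. The step between compound 2 and compound 4 cannot be read because both values are limits: the limit of > 10000 nM in this assay, at which 2 of the 4 values shown sit.

Of the compounds shown, only compound 3 has a hydrogen-bond donor on this carbon, so they cannot tell whether the donor is what matters. An amine at the same place would be a further test.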